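A few compounds are considered here, and "the series" means these few. Any claim that something is new, unique, unknown or untested is made for them only; others in the source may bear on it.

Compound 1 `CCC1(Cc2ccccc2)OS(=O)(=O)C=C1OCc1ccc(Cl)cc1` was tested in an ADME assay on HEL cells (Homo sapiens) for cytotoxicity, with a stated time of 3 days (on this read-out higher numbers stand for lower toxicity in this test and lower numbers for higher toxicity in this test), where compound 1 gives > 200000 nM, which is a limit of the assay rather than a number. This is all that is known for compound 1, and it sits at the limit of > 200000 nM in this assay, at which 1 of the 3 values shown sits. Two related compounds give numbers in this assay: compound 2 `CCCC1(Cc2ccccc2)OS(=O)(=O)C=C1OCc1ccccc1` gives 200000 nM, and compound 3 `CC(C)CC1(Cc2ccccc2)OS(=O)(=O)C=C1OCc1ccccc1` gives 102000 nM. Going by the values given here, the single step between measured compounds that differ in one place is a 2.0-fold lower number from compound 2 to compound 3 (0.29 log units; within the scatter); it concerns the saturated chain and not the benzyl ether, so it does not bear on the change now in question.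

Compound 4 `CCC1(Cc2ccccc2)OS(=O)(=O)C=C1OCC=C(C)C` has not yet been measured in this assay. It differs from compound 1 as follows: 2-methylprop-1-en-1-yl in place of 4-chlorophenyl on a saturated chain carbon bound to an oxygen on an unsaturated carbon. Among the compounds with values here, no measured step touches this part of the molecule, so the expectation rests on how closely the three measured values sit together and on the limit recorded for compound 1. Compound 4 is accordingly expected to show a step of an at least 1.1-fold lower number from compound 1 to compound 4 (0.04 log units; that floor lies within the scatter), which is no change beyond the scatter. The estimate for compound 4 in this assay is 180000 nM, with a range from 60000 nM to 400000 nM.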

Compound 4, half-maximal cytotoxic concentration: 112000 nM
Beside the measured number, compound 4's estimate is 1.6-fold (0.21 log units) above it, within the range that was stated.
By their numbers in this assay, from the lowest: compounds 3, 4 and 2 (each within the scatter of the next).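

Going by these compounds alone, this is the first step at this position, where 2-methylprop-1-en-1-yl replaces 4-chlorophenyl on a saturated chain carbon bound to an oxygen on an unsaturated carbon, and in this assay it reads as an at least 1.7-fold lower number from compound 1 to compound 4 (0.25 log units; that floor lies within the scatter). Compound 1 stands at a limit of the assay and not at a number: the limit of > 200000 nM in this assay, at which 1 of the 4 values shown sits. As far as these compounds go, the step therefore gives only a floor that lies within the scatter, so the change from 4-chlorobenzyl to 3-methylbut-2-en-1-yl, which removes the aromatic ring from this group, brings a measured number for compound 4 but no shift that can be called real, and its full size stays unknown.

The compounds shown leave open how a longer saturated chain, an amine or a carboxylic acid at this position would read in this assay. From the compounds shown here alone, whether the chlorine of compound 1 has any effect of its own in this test also stays open, as does the size of the step from compound 1 to compound 4.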